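A few compounds are considered here, and "the series" means these few. Any claim that something is new, unique, unknown or untested is made for them only; others in the source may bear on it.

Compound 3 `CC(C(=O)N1CCN(c2cccc(F)c2)CC1)N1C(=O)CCC1=O` is one of three measured members of a small series of succinimide amides built on a shared core. In a functional assay on the whole organism (strain Swiss) with Mus musculus as the target, in the maximal electroshock model, with a stated time of 2 h, at a dose of 100 mg/kg by the intraperitoneal route (a lower number here means a weaker effect, a higher number a stronger effect of the compound at the dose given), compound 3 gives 0%, and it stands level with both of its neighbours: compound 1 `COc1cccc(N2CCN(C(=O)C(C)N3C(=O)CCC3=O)CC2)c1` gives 0%, and compound 2 `COCC(C(=O)N1CCN(c2cccc(C(F)(F)F)c2)CC1)N1C(=O)CCC1=O` gives 0%. Among the compounds with values here, the only single-point step among them, no change at the digits printed from compound 1 to compound 3 (within the scatter), shows that exchanging methoxy for fluoro on the aromatic carbon left the read-out where it was.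

Compound 4 `CC(C(=O)N1CCN(c2cccc(C(F)(F)F)c2)CC1)N1C(=O)CCC1=O` has not yet been measured. It differs from compound 3 by trifluoromethyl in place of fluoro on an aromatic carbon. Within the data shown here, the step from compound 1 to compound 3 is the one measured step that bears on this change, and it was flat; compound 2 already carries the trifluoromethyl group and gives the same read-out as the others. Among the measured compounds shown here, nothing among the measured compounds therefore points to a move in either direction, and the step from compound 3 to compound 4 is expected to be no change at the digits printed from compound 3 to compound 4 (within the scatter), no change beyond the scatter. Compound 4 is accordingly estimated to give 0% in this assay, between 0% and 10%.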

Compound 4, a percentage reported as activity, at one dose (the size of the read-out at that dose, not a potency): 0%
Estimate against measurement, compound 4: no gap at the digits printed, within the range that was stated.
By their numbers in this assay, from the lowest: compounds 1, 2, 3 and 4 (each within the scatter of the next).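

Trifluoromethyl in place of fluoro on the aromatic carbon gives no change at the digits printed from compound 3 to compound 4 (within the scatter) and trifluoromethyl in place of methoxy there gives no change at the digits printed from compound 1 to compound 4 (within the scatter) in this assay, so methoxy, fluoro and trifluoromethyl at this position can now be compared directly, and none stands apart from the others. Hydrogen in place of methoxy on the saturated chain carbon gives no change at the digits printed from compound 2 to compound 4 (within the scatter) and adds a first reading at a second position, which is just as flat. No measurement here offers an explanation for these flat steps.

With all four compounds level in this assay, the steps do not show which changes, if any, could raise the read-out. Whether an amine, a carboxylic acid or a longer chain at either position would give a measurable effect remains open, as does the behaviour of these compounds at another dose or time.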